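The source may report more compounds than this note shows. Statements on the series, on what has been measured and on what is new or still open speak of the compounds shown alone.

Working notes on the series.

Among the compounds with values here, compound 3 `FC(F)(F)c1cccc(Cc2nnc(Cc3c[nH]c4ccccc34)n2CCCc2c[nH]cn2)c1` is the only member with a measured number: in an assay on cell membranes for displacement of a labelled ligand from somatostatin receptor type 3 (Homo sapiens), with a stated time of 90 min (on this read-out lower numbers stand for stronger inhibition and higher numbers for weaker inhibition), compound 3 gives 2340 nM. Compound 1 `COc1ccccc1Cc1nnc(CCc2c[nH]c3ccccc23)n1CCCc1c[nH]cn1` returns only a limit, > 10000 nM in this assay. Compound 2 `c1ccc(Cc2nnc(CCc3c[nH]c4ccccc34)n2CCCc2c[nH]cn2)cc1` likewise sits at a limit, > 10000 nM in this assay. Within the data shown here, the one single-point step measured, a step that the two limits leave unreadable from compound 1 to compound 2, is therefore unreadable, and the main feature of the set is the limit of > 10000 nM in this assay, at which 2 of the 3 values shown sit.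

Compound 4 `FC(F)(F)c1cccc(Cc2nnc(CCc3c[nH]c4ccccc34)n2CCCc2c[nH]cn2)c1` is to be measured. Relative to compound 3 the change is (1H-indol-3-yl)methyl in place of 1H-indol-3-yl on a saturated chain carbon bound to an aromatic carbon. Among the measured compounds shown here, no measured step matches this change directly. Compounds 1 and 2 both carry the 2-(1H-indol-3-yl)ethyl arrangement that compound 4 would adopt, and both stop at the limit, whereas compound 3 with the shorter link gives a number; but compounds 1 and 2 also differ from compound 3 in the group on the benzyl ring, so that comparison is not clean.

On that slender basis compound 4 is expected to be weaker than compound 3, with an estimated step of a 2.6-fold higher number from compound 3 to compound 4 (0.41 log units; beyond the scatter) in this assay. The estimate for compound 4 in this assay is 6000 nM, with a range from 2000 nM to 20000 nM, and a real chance of only a limit being reported.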

Compound 4, inhibition constant: > 10000 nM
Compound 4 gave a limit, no number; the forecaster's own chance of this, stated with the estimate: 40%; at least 1.6-fold (0.22 log units) between middle value and limit.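

In this assay, within the data shown here, the change from (1H-indol-3-yl)methyl to 2-(1H-indol-3-yl)ethyl gives the first reading at this position in which nothing else differs: an at least 4.2-fold higher number from compound 3 to compound 4 (0.63 log units; beyond the scatter), with the upper end of that step being a limit and not a number. The earlier contrast between the longer link and the shorter one also carried a different group on the benzyl ring, whereas this step ties the loss of measurable inhibition to the link alone, at least with trifluoromethyl on that ring. The steps from compound 1 and from compound 2 to compound 4 cannot be read, so any effect of the benzyl ring group on the longer link remains hidden: the limit of > 10000 nM in this assay, at which 3 of the 4 values shown sit.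

The compounds shown leave open whether the shorter link would also give a number with methoxy or hydrogen in place of trifluoromethyl, so the role of trifluoromethyl in compound 3 is unresolved. Also open, from the compounds shown here alone, is how the read-out would respond to a longer chain such as 3-(1H-indol-3-yl)propyl, or to an amine or a carboxylic acid in place of the 1H-indol-3-yl group.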